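Changing the Group on the Ester Carbonyl

A few compounds are considered here, and "the series" means these few. Any claim that something is new, unique, unknown or untested is made for them only; others in the source may bear on it.

- Compound 1 `CC1=CC[C@H]2[C@H](CC[C@]2(C)O)C(C)(C)[C@@H]1CC[C@H]1[C@]2(C)CC[C@H](OC(=O)c3ccc(Cl)cc3)C(C)(C)O[C@H]2CC[C@@]1(C)O`: 24100 nM
- Compound 2 `CC1=CC[C@H]2[C@H](CC[C@]2(C)O)C(C)(C)[C@@H]1CC[C@H]1[C@]2(C)CC[C@H](OC(=O)NCc3ccccc3)C(C)(C)O[C@H]2CC[C@@]1(C)O`: 24500 nM
- Compound 3 `CC1=CC[C@H]2[C@H](CC[C@]2(C)O)C(C)(C)[C@@H]1CC[C@H]1[C@]2(C)CC[C@H](OC(=O)c3ccc(C(F)(F)F)cc3F)C(C)(C)O[C@H]2CC[C@@]1(C)O`: > 50000 nM (a limit)

The account is set in a functional assay on MCF7 cells (Homo sapiens) for antiproliferative activity, read by MTT assay, with a stated time of 72 h; on this read-out higher numbers stand for weaker inhibition and lower numbers for stronger inhibition. Compound 3 stands only at a limit, > 50000 nM, and not at a number.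

Compound 4 `CC1=CC[C@H]2[C@H](CC[C@]2(C)O)C(C)(C)[C@@H]1CC[C@H]1[C@]2(C)CC[C@H](OC(=O)c3ccco3)C(C)(C)O[C@H]2CC[C@@]1(C)O` has furan-2-yl in place of 2-fluoro-4-(trifluoromethyl)phenyl on a carbonyl carbon. Three measured steps change the group at this same place. Benzylamino in place of 4-chlorophenyl gives a 1.0-fold higher number from compound 1 to compound 2 (0.01 log units; within the scatter). The 2-fluoro-4-(trifluoromethyl)phenyl group in place of 4-chlorophenyl gives an at least 2.0-fold higher number from compound 1 to compound 3 (0.31 log units; beyond the scatter), and in place of benzylamino it gives an at least 2.0-fold higher number from compound 2 to compound 3 (0.30 log units; that floor lies within the scatter).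

Compound 4 is therefore expected to return towards the values of compound 1 and compound 2, with a modest move to a lower number, similar in size to an at least 2.0-fold higher number from compound 1 to compound 3 (0.31 log units; beyond the scatter). Reaching the limit again remains possible. The expected step is an at least 1.6-fold lower number from compound 3 to compound 4 (0.22 log units; that floor lies within the scatter). In this assay the estimate for compound 4 is 30000 nM, with an expected range of 13000 nM to 60000 nM.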

Compound 4, half-maximal inhibitory concentration: 25700 nM
Compound 4: middle estimate off by 1.2-fold (0.07 log units), on the high side; low and high end bracket the measured number.
By their numbers in this assay, from the lowest: compounds 1, 2 and 4 (each within the scatter of the next). At a limit, above all of these: compound 3.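

Furan-2-yl on this carbonyl carbon gives a value in this assay level with those of the 4-chlorophenyl and benzylamino groups, with a 1.1-fold higher number from compound 1 to compound 4 (0.03 log units; within the scatter) and a 1.0-fold higher number from compound 2 to compound 4 (0.02 log units; within the scatter), so three quite different groups read alike here and only compound 3 stands apart. Replacing 2-fluoro-4-(trifluoromethyl)phenyl with furan-2-yl gives an at least 1.9-fold lower number from compound 3 to compound 4 (0.28 log units; that floor lies within the scatter), a step known only as a floor. Compound 3 is held at a limit and not at a number: the limit of > 50000 nM in this assay, at which 1 of the 4 values shown sits.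

The compounds shown do not tell whether the fluoro or the trifluoromethyl substituent of compound 3 goes with this step. They also leave open how an amine, a carboxylic acid or a cyclohexyl group on this carbonyl carbon would read in this assay, and whether any group here can give a clearly lower number.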